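From Compound 2 to Compound 3 in Thromboxane Antagonism

A few compounds are considered here, and "the series" means these few. Any claim that something is new, unique, unknown or untested is made for them only; others in the source may bear on it.

In a functional assay on HEK293 cells for antagonist activity at thromboxane A2 receptor (Homo sapiens), read by fluorescence and calcium flux (a higher number here means a weaker inhibitor, a lower number a stronger inhibitor), compound 2 `CC(C)NC(=O)NS(=O)(=O)c1cc(C#N)ccc1Oc1ccc(Br)cc1` gives 9470 nM, the higher of the two numbers measured, while compound 1 `Cc1cccc(Oc2ccc(C#N)cc2S(=O)(=O)NC(=O)NC(C)C)c1` gives 2380 nM; the step of a 4.0-fold higher number from compound 1 to compound 2 (0.60 log units; beyond the scatter) separates them. Compound 3 `CC(C)NC(=O)NS(=O)(=O)c1cc(C#N)ccc1Nc1ccc(F)cc1` differs from compound 2 by (4-fluorophenyl)amino in place of 4-bromophenoxy on an aromatic carbon. Within the data shown here, no measured step replaces the whole 4-bromophenoxy group, so the only guide is the modest shift between compound 1 and compound 2, which touched just the ring on that group. For compound 3 the expected step is a 1.6-fold lower number from compound 2 to compound 3 (0.20 log units; within the scatter), uncertain in direction. The estimate for compound 3 is 6000 nM, ranging from 1200 nM to 30000 nM.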

Compound 3, half-maximal inhibitory concentration: 8170 nM
For compound 3 the middle estimate is 1.4-fold (0.13 log units) below the measured one, and the stated range covers the measured number.
By their numbers in this assay, from the lowest: compound 1; then compounds 3 and 2 (each within the scatter of the next).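

Replacing 4-bromophenoxy with (4-fluorophenyl)amino gives a 1.2-fold lower number from compound 2 to compound 3 (0.06 log units; within the scatter) and so leaves these two compounds indistinguishable here, even though the linking oxygen and the ring's halogen both changed. Against the 3-methylphenoxy group, the same (4-fluorophenyl)amino group gives a 3.4-fold higher number from compound 1 to compound 3 (0.54 log units; beyond the scatter) and so stays on the weaker side of compound 1. No evidence at hand explains either result. As far as these compounds go, with both parts changing together, their separate contributions remain unknown. A sulfur or methylene link carrying the 3-methylphenyl ring could show whether the link or the ring matters more.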